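Quinolinone hydroxamate: swapping the benzyl aryl ring

A few compounds are considered here, and "the series" means these few. Any claim that something is new, unique, unknown or untested is made for them only; others in the source may bear on it.

Measured so far:
compound 1 `O=C(O)c1cn(Cc2ccc(Cl)cc2)c2ccccc2c1=O`: 28.7%
compound 2 `O=C(NO)c1cn(Cc2ccc(Cl)cc2)c2ccccc2c1=O`: 31.7%

Both compounds share one core and were tested in a functional assay, tested at 100 uM; on this read-out lower numbers stand for a weaker effect and higher numbers for a stronger effect at the one concentration tested. Compound 1 gives 28.7%. Among the measured compounds shown here, compound 2 gives 31.7%, and the one measured step, a number 3 percentage points higher from compound 1 to compound 2 (within the scatter), replaces hydroxy with hydroxyamino on a carbonyl carbon. On these two numbers compound 2 stands highest, with compound 1 nearest, but the two values sit within the scatter of each other, so no order between them is claimed.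

Compound 3 `O=C(NO)c1cn(Cc2ccc(O)c(O)c2)c2ccccc2c1=O` has not yet been measured. It differs from compound 2 as follows: 3,4-dihydroxyphenyl in place of 4-chlorophenyl on a saturated chain carbon bound to an aromatic nitrogen. For the measured compounds named here, no measured step touches this place; the only step known concerns the carbonyl carbon and was within the scatter, so it gives no guide to the size or direction of the change in this assay here. With nothing to point either way, a step of a number 3.3 percentage points higher from compound 2 to compound 3 (within the scatter) is expected, that is, none beyond the scatter. Compound 3 is therefore estimated at 35%, with a range from 15% to 60%.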

Compound 3, a percentage reported as activity, at one concentration (the size of the read-out at that concentration, not a potency): 88.1%
Estimate against measurement, compound 3: 53.1 percentage points below; the measured number lies above the stated range.
By their numbers in this assay, from the lowest: compounds 1 and 2 (each within the scatter of the next); then compound 3.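

In this assay, the group on the saturated chain carbon bound to an aromatic nitrogen proves to be a place where the read-out responds strongly: 3,4-dihydroxyphenyl in place of 4-chlorophenyl gives a number 56.4 percentage points higher from compound 2 to compound 3 (beyond the scatter). The earlier step on the carbonyl carbon stayed within the scatter, so this is the first change among the compounds shown to move the number beyond it, and the aryl ring on this chain carbon matters more here than that earlier swap. The entering group has 2 hydrogen-bond donors and 2 hydrogen-bond acceptors where the leaving group has 0 of each, but nothing at hand says which feature of the swap, if any single one, accounts for the rise.

On these data alone, it remains open whether both hydroxy groups are needed, or whether a phenyl ring with a single hydroxy group, or one with methoxy groups or an amine in their place, would give a similar number. As far as these compounds go, it is also open whether the carboxylic acid and the hydroxyamino carbonyl stay within the scatter of each other once the 3,4-dihydroxyphenyl group is present.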